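The source may report more compounds than this note shows. Statements on the series, on what has been measured and on what is new or still open speak of the compounds shown alone.

Measured compounds:
compound 1 `CCOc1cc(/C=C(\C(=O)c2ccc(Cl)cc2)S(=O)(=O)Cc2ccc(Cl)cc2)ccc1O` gives 10000 nM;
compound 2 `Cc1ccc(S/C(=C/c2ccc(Cl)c(Cl)c2)C(=O)c2ccc(Br)cc2)cc1` gives 50000 nM;
compound 3 `O=C(/C(=C/c1ccc(Cl)cc1)Cc1c[nH]c2ccccc12)c1ccc(Cl)cc1Cl` gives 10000 nM.

All three numbers come from a functional assay on DU-145 cells (Homo sapiens) for inhibition, read by trypan blue exclusion, with a stated time of 96 h; a lower number here means a stronger inhibitor of growth, a higher number a weaker inhibitor of growth. Among them compound 2 stands highest: compound 1 and compound 3 each sit beyond the scatter below it, and both of them sit at the same value, so compound 2 is the weakest inhibitor of growth in this set.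

Compound 4 `Cc1ccc(S/C(=C/c2ccc(N(C)C)cc2)C(=O)c2ccc(Br)cc2)cc1` has not been measured in this assay. It differs from compound 2 in one place: 4-(dimethylamino)phenyl in place of 3,4-dichlorophenyl on a double-bonded chain carbon bound to a double-bonded chain carbon.

For the measured compounds named here, no step between two measured compounds matches this change, so the three values give no direct guide to its size. A modest step toward a lower number is expected, though it may well stay within the scatter. Compound 4 is therefore estimated at 30000 nM, with a range from 8000 nM to 100000 nM. The step from compound 2 to compound 4 that this estimate implies is a 1.7-fold lower number from compound 2 to compound 4 (0.22 log units; within the scatter).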

Compound 4, concentration for 50% growth inhibition: > 100000 nM
Compound 4: a limit, no number; the forecaster's own chance of this, stated with the estimate: 25%; middle value at least 3.3-fold (0.52 log units) from the limit.
By their numbers in this assay, from the lowest: compounds 1 and 3 (each within the scatter of the next); then compound 2. At a limit, above all of these: compound 4.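

In this assay compound 4 gives > 100000 nM, which is a limit and not a number. On a double-bonded chain carbon bound to a double-bonded chain carbon, 4-(dimethylamino)phenyl in place of 3,4-dichlorophenyl gives an at least 2.0-fold higher number from compound 2 to compound 4 (0.30 log units; that floor lies within the scatter), so this change brought no lower number, and how far the step runs past that floor cannot be read. The compounds shown leave open whether a phenyl carrying a carboxylic acid or a methoxy group at this place would lower the number, and whether the same change would act alike on the cores of compound 1 and compound 3.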